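A few compounds are considered here, and "the series" means these few. Any claim that something is new, unique, unknown or untested is made for them only; others in the source may bear on it.

Compound 1 `Cc1cc(-c2nc3sc(C)cn3c2/C=N/NC(=N)N)c(C)s1`: 33100 nM
Compound 2 `Cc1cn2c(/C=N/Nc3ccccn3)c(-c3ccc(Cl)c([N+](=O)[O-])c3)nc2s1`: 25700 nM
Compound 3 `N=C(N)N/N=C/c1c(-c2cc(Cl)sc2Cl)nc2n1CCS2`: 22900 nM

In a functional assay on cells (Cancer cell lines, Homo sapiens) for inhibition (on this read-out lower numbers stand for stronger inhibition of growth and higher numbers for weaker inhibition of growth), compound 1 gives 33100 nM, which lies within the scatter of both other values, so the three cannot be ranked. The unmeasured compound 4 `Cc1cc(-c2nc3sccn3c2/C=N/NC(=N)N)c(C)s1` differs from compound 1 in one place: hydrogen in place of methyl on an aromatic carbon. No measured pair shows a single change of this kind in this assay. Compound 2 at 25700 nM and compound 3 at 22900 nM both stay within the scatter of compound 1, so no change beyond the scatter is expected, in either direction. The expected step of a 1.1-fold lower number from compound 1 to compound 4 (0.04 log units; within the scatter) is estimated to stay within the scatter. For compound 4 the estimated value is 30000 nM, with an expected range from 15000 nM to 60000 nM.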

Compound 4, concentration for total growth inhibition: 33900 nM
For compound 4 the middle estimate is 1.1-fold (0.05 log units) below the measured one, within the range that was stated.
By their numbers in this assay, from the lowest: compounds 3, 2, 1 and 4 (each within the scatter of the next).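

In this assay, among the compounds shown here, compound 1 and compound 4 form the first pair that differs in one place, and they isolate hydrogen in place of methyl on an aromatic carbon next to the ring sulfur. The change gives a 1.0-fold higher number from compound 1 to compound 4 (0.01 log units; within the scatter), so removing this methyl leaves the read-out within the scatter on this core. On these data alone, whether an ethyl group, a methoxy group or an amine at this position would also stay within the scatter remains open. What the unchanged read-out reflects is open too, as no other measurement bears on this result.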